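The source may report more compounds than this note shows. Statements on the series, on what has been measured and on what is new or still open speak of the compounds shown alone.

Compound 3 `Clc1ccc(Oc2ccc3nncn3n2)cc1` gives 36.7 mg/kg in a functional assay on the whole organism with Mus musculus as the target (a higher number here means that more compound is needed for the effect, a lower number that less compound is needed), the lowest of the two numbers shown; compound 2 `Clc1ccccc1Oc1ccc2nncn2n1` gives 47.3 mg/kg, which sits within the scatter of it. Compound 1 `COc1ccc(Oc2ccc3nncn3n2)cc1` reaches only a limit in this assay, > 100 mg/kg. Compound 4 `Clc1ccc(Oc2ccc3nncn3n2)c(Cl)c1` differs from compound 3 by chloro in place of hydrogen on an aromatic carbon. Among the measured compounds shown here, the one measured step that bears on this change is an at least 2.7-fold lower number from compound 1 to compound 3 (0.43 log units; beyond the scatter), though it rests on a limit of > 100 mg/kg in this assay, at which 1 of the 3 values shown sits, and swaps a different group rather than a hydrogen. A second chloro is therefore expected to bring at most a modest lowering in this assay, or none beyond the scatter. For compound 4 the estimate is 25 mg/kg, with a range from 10 mg/kg to 60 mg/kg. The expected step is a 1.5-fold lower number from compound 3 to compound 4 (0.17 log units; within the scatter).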

Compound 4, dose for half-maximal effect: 17.3 mg/kg
Estimate against measurement, compound 4: 1.4-fold (0.16 log units) above; the measured number falls inside the stated range.
By their numbers in this assay, from the lowest: compound 4; then compounds 3 and 2 (each within the scatter of the next). At a limit, above all of these: compound 1.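

Replacing a hydrogen with chloro on its own, with no other group swapped and no limit involved, lowers the number in this assay beyond the scatter. The chloro set ortho to a large group and meta to a chloro group gives a 2.1-fold lower number from compound 3 to compound 4 (0.33 log units; beyond the scatter), and the same ring with its two chloro groups also stands clear of the other single-chloro compound, with a 2.7-fold lower number from compound 2 to compound 4 (0.44 log units; beyond the scatter). Compound 2 and compound 3 lay within the scatter of each other, so only the second chloro separates a compound from them.

Nothing shown accounts for this lowering. On these data alone, whether a fluoro, a methyl or a trifluoromethyl at this position would do the same, or an amine or a carboxylic acid would be tolerated there, stays open.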